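The source may hold more compounds than are shown below. What is called first, only, known or untested is meant among the compounds shown, and "the series" means these compounds.

Working notes on a small series of bromoacrylamide chalcones measured for growth inhibition.

Compound 1 `C=C(Br)C(=O)Nc1ccc(C(=O)/C=C/c2ccc(OC)cc2)cc1` gives 900 nM in a functional assay on L1210 cells (Mus musculus) for antiproliferative activity, with a stated time of 48 h; on this read-out higher numbers stand for weaker inhibition and lower numbers for stronger inhibition. Compound 2 `C=C(Br)C(=O)Nc1ccc(C(=O)/C=C/c2cccc(OC)c2)cc1` gives 1100 nM in this assay. For the measured compounds named here, the single step between them, a 1.2-fold higher number from compound 1 to compound 2 (0.09 log units; within the scatter), replaces 4-methoxyphenyl with 3-methoxyphenyl and does not move the number beyond the scatter. Compound 2 thus holds the highest of the two numbers shown, but its only neighbour, compound 1, lies within the scatter of it, so no order between the two can be read.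

Compound 3 `C=C(Br)C(=O)Nc1ccc(C(=O)/C=C/c2ccc(OC)c(OC)c2)cc1` differs from compound 2 by methoxy in place of hydrogen on an aromatic carbon. Going by the values given here, no measured step adds a methoxy group to a ring that already carries one; the only step available, from compound 1 to compound 2, concerns where a single methoxy group sits and was within the scatter. With that as the sole reference, no movement beyond the scatter is expected in this assay for compound 3. Compound 3 is therefore estimated at 1000 nM, with a range of 400 nM to 2500 nM. The step this estimate implies, a 1.1-fold lower number from compound 2 to compound 3 (0.04 log units; within the scatter), is expected to stay within the scatter.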

Compound 3, half-maximal inhibitory concentration: 1300 nM
Beside the measured number, compound 3's estimate is 1.3-fold (0.11 log units) below it; measured number inside the range.
By their numbers in this assay, from the lowest: compounds 1, 2 and 3 (each within the scatter of the next).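

In this assay, for the compounds shown here, methoxy in place of hydrogen on the aromatic carbon ortho to a methoxy group and para to a large group gives a first reading for this kind of change (a 1.2-fold higher number from compound 2 to compound 3 (0.07 log units; within the scatter)). The same change read from the other monomethoxy compound stays within the scatter as well (a 1.4-fold higher number from compound 1 to compound 3 (0.16 log units; within the scatter)), so neither available comparison moves the number beyond it. This position therefore takes a methoxy group with no measurable shift in this series, and no independent measurement bears on the result.

From the compounds shown here alone, all three compounds carry only methoxy groups on this ring, so it remains open whether a hydroxy group, an amine, a carboxylic acid or a longer chain such as ethoxy at this position would move the number beyond the scatter. Also open, going by these compounds, are the ring with no methoxy group at all and any change to the shared core outside this ring, including the bromine-bearing acrylamide.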